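The source may report more compounds than this note shows. Statements on the series, on what has been measured and on what is new or still open speak of the compounds shown alone.

Series notes. The two measured compounds share one core and differ only in the group on the phenyl ring of the hydrazone. Compound 1 `CC1CC/C(=N\Nc2ccc(O)cc2)c2ncc(C(=O)O)c(=O)n21` gives in a functional assay on the whole organism for inhibition, with Rattus norvegicus as the target (a lower number here means that less compound is needed, a higher number that more compound is needed for the effect), a value of 1.7 umol/kg. Among the measured compounds shown here, compound 2 `COc1ccc(N/N=C2\CCC(C)n3c2ncc(C(=O)O)c3=O)cc1` gives in this assay a value of 0.8 umol/kg, the lowest of the two numbers so far; the only measured step, a 2.1-fold lower number from compound 1 to compound 2 (0.33 log units; beyond the scatter), is modest but beyond the scatter.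

Compound 3 `Cc1ccc(N/N=C2\CCC(C)n3c2ncc(C(=O)O)c3=O)cc1` carries methyl in place of methoxy on an aromatic carbon. For the measured compounds named here, no measured pair shows a methoxy replaced by a methyl at this place, so the single known step on this ring offers no direct guide; it shows only that a small change here moved the number modestly. The expectation for compound 3 in this assay is therefore a step within the scatter, a 1.3-fold higher number from compound 2 to compound 3 (0.10 log units; within the scatter), in no firm direction. Compound 3 is estimated at 1 umol/kg, with a range from 0.4 umol/kg to 2.5 umol/kg.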

Compound 3, dose for 50% inhibition: 1.3 umol/kg
Compound 3: the middle estimate sits 1.3-fold (0.11 log units) below what was measured; the range from low to high includes it.
By their numbers in this assay, from the lowest: compounds 2, 3 and 1 (each within the scatter of the next, the first and the last beyond it).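

Working notes on the 4-methoxyphenyl to 4-methylphenyl change. In this assay, replacing methoxy with methyl, para to a large group, gives a step within the scatter (a 1.6-fold higher number from compound 2 to compound 3 (0.21 log units; within the scatter)), so an oxygen on this aromatic carbon is not needed to stay level with compound 2. Methyl in place of hydroxy is also within the scatter (a 1.3-fold lower number from compound 1 to compound 3 (0.12 log units; within the scatter)), which leaves compound 3 unresolved from both neighbours, even though compound 1 and compound 2 lie beyond the scatter of each other. No measurement on hand accounts for these numbers.

The compounds shown cover only hydroxy, methoxy and methyl at this place, all small groups, so the result of an amine or a longer chain here remains open. On these data alone, whether any group on this ring can move the number well beyond this narrow span also remains open.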